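Inverting One Ring Stereocentre in a Bradykinin Antagonist Series

The source may report more compounds than this note shows. Statements on the series, on what has been measured and on what is new or still open speak of the compounds shown alone.

Compound 1 `Cc1ccc(S(=O)(=O)N2C=CNC(=O)[C@H]2CC(=O)N[C@@H]2CCC(=O)c3ccccc32)cc1`: 40.8 nM
Compound 2 `CN1CC[C@H](NC(=O)C[C@@H]2C(=O)NC=CN2S(=O)(=O)c2cccc(Cl)c2Cl)C(C)(C)C1`: 0.22 nM
Compound 3 `CN(C)[C@H]1CCN(C(=O)C[C@@H]2C(=O)NC=CN2S(=O)(=O)c2cccc(Cl)c2Cl)C1`: 20.3 nM

These three compounds were tested in an in vitro functional assay on cells for antagonist activity at B1 bradykinin receptor (Homo sapiens), read by luminescence and calcium flux, with a stated time of 2 h; on this read-out lower numbers stand for stronger inhibition and higher numbers for weaker inhibition. Compound 3 gives 20.3 nM, the second highest number of the three; compound 1 lies nearest, at a gap within the scatter, and compound 2 lies furthest, at a gap beyond it. Among the compounds with values here, the single measured step, a 92-fold higher number from compound 2 to compound 3 (1.97 log units; beyond the scatter), swaps one saturated ring for another and does not test configuration on its own. Compound 4 `CN(C)[C@@H]1CCN(C(=O)C[C@@H]2C(=O)NC=CN2S(=O)(=O)c2cccc(Cl)c2Cl)C1` is related to compound 3 as follows: the two compounds have the same atoms and bonds and differ only in configuration as drawn: 1 of 2 stereo elements differ; a stereocentre at a saturated ring carbon is drawn S in compound 3 and R in compound 4. Within the data shown here, no measured step bears on such an inversion, so the direction in this assay is open. Compound 4 is estimated at 8 nM, between 0.8 nM and 80 nM, a step of a 2.5-fold lower number from compound 3 to compound 4 (0.40 log units; beyond the scatter).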

Compound 4, half-maximal inhibitory concentration: 130 nM
Estimate against measurement, compound 4: 16-fold (1.21 log units) below, and the stated range ends below it.
By their numbers in this assay, from the lowest: compound 2; then compounds 3 and 1 (each within the scatter of the next); then compound 4.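

In this assay, the configuration at this saturated ring carbon matters on its own, with the S form giving the lower number: a 6.4-fold higher number from compound 3 to compound 4 (0.81 log units; beyond the scatter). This gap can be assigned to that single stereocentre because nothing else separates the pair: the fact that compounds 3 and 4 differ only in the configuration as drawn. The R form also stands further from the six-membered ring amide: a 590-fold higher number from compound 2 to compound 4 (2.77 log units; beyond the scatter).

The compounds shown leave open whether inverting the corresponding ring carbon in compound 2 would shift its number in the same direction. They also leave open whether the S preference would hold with a morpholine or a diethylamino group on the five-membered ring.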